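Sulfonyl replacement on the compound 3 scaffold

The source may report more compounds than this note shows. Statements on the series, on what has been measured and on what is new or still open speak of the compounds shown alone.

Measured so far in a physicochemical assay for lipophilicity, measured as octanol-water partition, at pH 7.4; a higher number here means a more lipophilic compound, a lower number a more polar compound
compound 1 `Cc1ccc2[nH]c(C(=O)N[C@H]3CN(S(=O)(=O)c4ccccc4)C[C@@H]3C(=O)NCCN(C)C)cc2c1` gives 2.1
compound 2 `Cc1ccc2[nH]c(C(=O)N[C@H]3CN(S(=O)(=O)C4CCOCC4)C[C@@H]3C(=O)NCCN(C)C)cc2c1` gives 1
compound 3 `Cc1ccc2[nH]c(C(=O)N[C@H]3CCN(S(=O)(=O)c4ccccc4)C[C@@H]3C(=O)NCCN(C)C)cc2c1` gives 2.2
Not yet measured: compound 4 `Cc1ccc2[nH]c(C(=O)N[C@H]3CCN(S(=O)(=O)N4CCOCC4)C[C@@H]3C(=O)NCCN(C)C)cc2c1`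

Compound 3 (2.2) does not separate from compound 1 beyond the scatter, and compound 2 (1) stands clearly lower than both. The step to compound 4 puts morpholin-4-yl in place of phenyl on a sulfonyl sulfur. Going by the values given here, no compound carrying morpholin-4-yl has been measured, so the nearest guide is a single step (a number 1.10 log units lower from compound 1 to compound 2 (beyond the scatter)) with oxan-4-yl in place of phenyl on a sulfonyl sulfur. That step is large, and it was taken on the core of compound 1, not on that of compound 3. Among the compounds with values here, the change at the sulfonyl sulfur is otherwise closely comparable, so a drop of similar size in this assay is expected, with real uncertainty because only one step supports it. The estimate for this change (a number 1.00 log units lower from compound 3 to compound 4 (beyond the scatter)) carries over the direction and most of the size of the step to compound 2. The estimated value for compound 4 is 1.2 (expected range 0.8 to 1.6).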

Compound 4, distribution coefficient: 1
Estimate against measurement, compound 4: 0.20 log units above; the measured number falls inside the stated range.
By their numbers in this assay, from the lowest: compounds 2 and 4 (each within the scatter of the next); then compounds 1 and 3 (each within the scatter of the next).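

In this assay, the replacement of phenyl on a sulfonyl sulfur now gives a large fall on a second core, a number 1.20 log units lower from compound 3 to compound 4 (beyond the scatter), and with a different incoming group, morpholin-4-yl, whose ring is attached to the sulfur through nitrogen. Set beside the earlier step, a number 1.10 log units lower from compound 1 to compound 2 (beyond the scatter), this gives two cases with the same direction and a large size, and no compound in this small set goes against the pattern, so the fall no longer rests on oxan-4-yl or on the core of compound 1 alone. Nothing available explains the fall in terms of any feature of the groups exchanged.

Still open, from the compounds shown here alone, is whether piperidin-1-yl or cyclohexyl on the sulfonyl sulfur, each a non-aromatic ring without the ring oxygen, would give a fall of similar size, which would show whether removing phenyl is enough or the ring oxygen is also tied to the lower number. The two steps also sit on different cores, so the shown compounds give no direct comparison of oxan-4-yl with morpholin-4-yl on one shared core.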